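Methoxy Removal on Two Pyrazole Chalcone Cores

The source may hold more compounds than are shown below. What is called first, only, known or untested is meant among the compounds shown, and "the series" means these compounds.

In a functional assay on HOP-92 cells (Homo sapiens) for inhibition, read by sulforhodamine B assay, with a stated time of 48 h (a lower number here means a stronger inhibitor of growth, a higher number a weaker inhibitor of growth), compound 1 `COc1cc(-c2cc(/C=C/C(=O)c3ccc(N)cc3)[nH]n2)cc(OC)c1OC` gives 27600 nM and compound 2 `COc1ccc(-c2cc(/C=C/C(=O)c3ccc(N)cc3)[nH]n2)cc1OC` gives 30900 nM. The two share a core and differ in one place, (hydrogen in place of methoxy on an aromatic carbon), and the step of a 1.1-fold higher number from compound 1 to compound 2 (0.05 log units; within the scatter) is within the scatter of the method. Compound 3 `COc1cc(C(=O)/C=C/c2cc(-c3cc(OC)c(OC)c(OC)c3)n[nH]2)cc(OC)c1OC` is built on a different core; the difference between the two cores is not broken down here. In this assay compound 3 gives 1020 nM, the lowest number of the three measured compounds, and its distance from both compound 1 and compound 2 lies beyond the scatter.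

Compound 4 `COc1ccc(-c2cc(/C=C/C(=O)c3cc(OC)c(OC)c(OC)c3)[nH]n2)cc1OC` has not yet been measured. It differs from compound 3 in one place, (hydrogen in place of methoxy on an aromatic carbon), and the place described is word for word the same as the place of the change from compound 1 to compound 2, so it is the same change made on the other core. That change occurs twice among the compounds shown, once measured and once not. On the first core it moved the number hardly at all, as the step of a 1.1-fold higher number from compound 1 to compound 2 (0.05 log units; within the scatter) shows. Resting on that single precedent, compound 4 is expected to stay close to compound 3 in this assay, with an expected step of a 1.2-fold higher number from compound 3 to compound 4 (0.07 log units; within the scatter). The estimate for compound 4 in this assay is 1200 nM, expected to fall between 500 nM and 3000 nM.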

Compound 4, concentration for total growth inhibition: 5480 nM
Compound 4: middle estimate off by 4.6-fold (0.66 log units), on the low side; measured number outside the range, above it.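

On the core of compound 3, putting hydrogen in place of a methoxy on an aromatic carbon gave a 5.4-fold higher number from compound 3 to compound 4 (0.73 log units; beyond the scatter) in this assay, whereas the same change on the core of compound 1 gave a step that stayed within the scatter. The size of this change therefore cannot simply be carried from one core to the other in this series, as the two steps differ: the same change on two cores in this assay, a 1.1-fold higher number (0.05 log units; within the scatter) from compound 1 to compound 2 and a 5.4-fold higher number (0.73 log units; beyond the scatter) from compound 3 to compound 4, 4.8-fold (0.68 log units) apart, beyond the scatter of two such steps This rests on a single pair of compounds on each core, so it shows that the outcome depends on the core in these four compounds, but it does not show which part of the cores accounts for the gap, why the two steps differ, or whether the same would hold on any further core.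

As far as these compounds go, whether the step on the core of compound 3 is specific to the loss of that methoxy, or whether another group in the same place, such as a hydroxy group, an ethoxy group or a fluorine atom, would give a number nearer to compound 3 or to compound 4, remains open. Equally open is how any such group would behave on the core of compound 1, where the only step shown lies within the scatter.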